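This account rests on a few compounds, and the source may have more. Where it says the series, first, only, none or still open, it means among the compounds named here.

Three compounds in this set share one core and differ only in the group on the aromatic ring at the end of the side chain. Compound 1 `NC1=NC2(CCSCC2)N(OCCCOc2ccc(Cl)cc2)C(N)=N1` carries a chlorine on that ring and compound 2 `NC1=NC2(CCSCC2)N(OCCCOc2ccc(Br)cc2)C(N)=N1` a bromine. In an assay on isolated protein for inhibition of Dihydrofolate reductase (Homo sapiens), read by spectrophotometry, using NADPH, with stated times of 5 s and 6 min, tested at 50 uM (a lower number here means a weaker effect, a higher number a stronger effect of the compound at the concentration tested), compound 1 has "not determined" (no result reported), and compound 2 likewise has "not determined" (no result reported). Compound 3 `CC(C)(C)c1ccc(OCCCON2C(N)=NC(N)=NC23CCSCC3)cc1` carries a tert-butyl group on that ring; in this assay compound 3 gives 86.6%. Within the data shown here, this is the only number in the whole set, so compound 3 is the single fixed point, with nothing measured to set beside it.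

Compound 4 `COc1ccc(OCCCON2C(N)=NC(N)=NC23CCSCC3)cc1` is the next step. The change from compound 3 to compound 4 is methoxy in place of tert-butyl on an aromatic carbon. Among the measured compounds shown here, no measured pair shows a comparable swap, so the size of this step can only be judged from general experience. A strong inhibition at the tested concentration leaves little room upward, and exchanging one small group for another on this ring often costs only a little. The step is expected to be a modest fall, a number 11.6 percentage points lower from compound 3 to compound 4 (beyond the scatter), which may still lie within the scatter. For compound 4 the estimated result in this assay is 75%, most likely between 50% and 95%.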

Compound 4, a percentage reported as inhibition, at one concentration (the size of the read-out at that concentration, not a potency): 86.6%
The estimate for compound 4 lay 11.6 percentage points below the measured number, within the range that was stated.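

Among these compounds, exchanging tert-butyl for methoxy on an aromatic carbon of the end ring gives no change at the digits printed from compound 3 to compound 4 (within the scatter) in this assay, which is the first comparison the set allows. This position can therefore carry either the larger all-carbon group or the smaller oxygen-bearing one with no visible difference in this read-out, although the read-out gives only the size of the effect at the one concentration tested, so the two compounds could still differ in their effect at other concentrations. Nothing available explains why the two groups read alike.

Compound 1 and compound 2 carry no number, so the steps that involve their chlorine and bromine cannot be read. On these data alone, it stays open whether an amine or a carboxylic acid on the same aromatic carbon would keep the result of compound 3 and compound 4, and whether a longer chain between the core and the end ring would do so.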